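This account rests on a few compounds, and the source may have more. Where it says the series, first, only, none or still open, it means among the compounds named here.

Measured compounds in a functional assay on HCT-15 cells (Homo sapiens) for cytotoxicity, read by sulforhodamine B assay, with a stated time of 48 h; on this read-out higher numbers stand for weaker inhibition of growth and lower numbers for stronger inhibition of growth:

Compound 1 `Nc1nc(Cl)c2ncn(Cc3ccc(CCl)cc3)c2n1` gives 4900 nM.
Compound 2 `ClCc1ccccc1Cn1cnc2c(Cl)ncnc21` gives 2090 nM.
Compound 3 `ClCc1cccc(Cn2cnc3c(Cl)ncnc32)c1` gives 2180 nM.

Of the compounds shown here, three have been measured, and the number for compound 3 sits within the usual scatter of the number for compound 2, so the two cannot be told apart on this read-out. The number for compound 1 lies clearly higher, beyond the scatter, so compound 1 inhibits growth of these cells more weakly than compound 3 does.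

Compound 4 `ClCc1cccc(Cn2cnc3c(Cl)nc(Cl)nc32)c1` has not yet been measured. It differs from compound 3 in one place: chloro in place of hydrogen on an aromatic carbon. Going by the values given here, no pair of measured compounds shows what such a change does on this core, so the direction of the step has to be guessed. Adding one chlorine is a small change, and the step is expected to stay close to the scatter, with a slight lean toward stronger inhibition of growth. The expected step is a 1.5-fold lower number from compound 3 to compound 4 (0.16 log units; within the scatter). Compound 4 is therefore estimated at 1500 nM, with a range from 500 nM to 5000 nM.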

Compound 4, concentration for 50% growth inhibition: 2390 nM
The estimate for compound 4 lay 1.6-fold (0.20 log units) below the measured number, and the stated range covers the measured number.
By their numbers in this assay, from the lowest: compounds 2, 3 and 4 (each within the scatter of the next); then compound 1.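

In this assay, placing chloro in place of hydrogen on the aromatic carbon between two ring nitrogen atoms gives a 1.1-fold higher number from compound 3 to compound 4 (0.04 log units; within the scatter), so compound 3 and compound 4 cannot be told apart on this read-out. Going by these compounds alone, this is the first single-place change that can be read on this core, and it shows that a hydrogen at this carbon is not required for the growth inhibition seen with compound 3, since chloro there leaves the number within the scatter. Nothing available explains this result.

From the compounds shown here alone, what an amine, a methoxy group or a longer chain would do at this carbon remains open. Also open, going by these compounds, is whether chloro here would leave the number just as unmoved with the chloromethyl group placed as in compound 2.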